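Hydroxymethyl in place of hexyl on a shared quinoline-free core

The source may hold more compounds than are shown below. What is called first, only, known or untested is meant among the compounds shown, and "the series" means these compounds.

Measured so far:
Compound 1 `COc1nc2ccc(Br)cc2cc1C(c1ccccc1)n1cc(-c2cccc(F)c2)nn1` — 14.6%
Compound 2 `CCCCCCCCc1cn(C(c2ccccc2)c2cc3cc(Br)ccc3nc2OC)nn1` — 2.27%
Compound 3 `CCCCCCc1cn(C(c2ccccc2)c2cc3cc(Br)ccc3nc2OC)nn1` — 2.32%

In an ADME assay on PC-3 cells (Homo sapiens) for cytotoxicity, read by sulforhodamine B assay, with a stated time of 48 h, tested at 10 uM (on this read-out lower numbers stand for less inhibition and higher numbers for more inhibition at the one concentration tested (going by the name of the read-out)), compound 1 gives 14.6%, compound 2 gives 2.27% and compound 3 gives 2.32%. Compound 3 stands second highest of the three numbers, within the scatter of compound 2 and well below compound 1. The two steps that swap the 3-fluorophenyl for a chain are a number 12.3 percentage points lower from compound 1 to compound 2 (beyond the scatter) and a number 12.3 percentage points lower from compound 1 to compound 3 (beyond the scatter); the step that shortens the chain, a number 0.1 percentage points higher from compound 2 to compound 3 (within the scatter), is within the scatter.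

Compound 4 `COc1nc2ccc(Br)cc2cc1C(c1ccccc1)n1cc(CO)nn1` differs from compound 3 by hydroxy in place of pentyl on a saturated chain carbon bound to an aromatic carbon. Among the measured compounds shown here, no measured step puts a hydroxy at this place, so the only bearing steps are those from compound 1 to compounds 2 and 3, which show that replacing the 3-fluorophenyl drops inhibition modestly, and the step from compound 2 to compound 3, which shows that chain length itself changes nothing beyond the scatter. Compound 4 is therefore expected to stay near the low end, with a number 1.7 percentage points higher from compound 3 to compound 4 (within the scatter) expected to lie within the scatter. The estimate for compound 4 is 4%, between -6% and 14%.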

Compound 4, a percentage reported as inhibition, at one concentration (the size of the read-out at that concentration, not a potency): 4.65%
Estimate against measurement, compound 4: 0.7 percentage points below; low and high end bracket the measured number.
By their numbers in this assay, from the lowest: compounds 2, 3, 4 and 1 (each within the scatter of the next, the first and the last beyond it).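

In this assay, hydroxy in place of pentyl gives a number 2.3 percentage points higher from compound 3 to compound 4 (within the scatter), and hydroxy in place of heptyl gives a number 2.4 percentage points higher from compound 2 to compound 4 (within the scatter), so at this place a long alkyl chain and a hydroxymethyl cannot be told apart. Measured against the 3-fluorophenyl, hydroxymethyl gives a number 10 percentage points lower from compound 1 to compound 4 (within the scatter), whereas both alkyl chains fell beyond the scatter of compound 1; compound 4 thus lies within the scatter of all three earlier compounds and blurs the split between the aryl group and the chains. Nothing available explains these numbers or links them to any property of the groups.

Still open, on these data alone, is whether an amine or a carboxylic acid at this place would move the number beyond the scatter. As far as these compounds go, it is also open whether an unsubstituted phenyl would match the 3-fluorophenyl.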